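Removing a tert-butoxycarbonyl group from compound 2

The source may report more compounds than this note shows. Statements on the series, on what has been measured and on what is new or still open speak of the compounds shown alone.

Compound 1 `COC1=CC(=O)N(C(=O)/C=C/[C@H](C)NC(=O)[C@H](CC(C)C)N(C)C)[C@H]1Cc1ccccc1` gives 67000 nM
Compound 2 `CC[C@H](C)[C@H](NC(=O)OCc1ccccc1)C(=O)N[C@@H](CC(C)C)C(=O)N[C@@H](CC(C)C)C(=O)N[C@@H](C)/C=C/C(=O)N1C(=O)C=C(OC)[C@@H]1c1cn(C(=O)OC(C)(C)C)c2ccccc12` gives > 100000 nM

In a functional assay on PANC-1 cells (Homo sapiens) for antiproliferative activity, read by MTT assay, with a stated time of 48 h (a lower number here means a stronger inhibitor, a higher number a weaker inhibitor), compound 1 gives 67000 nM as a true measured number. Compound 2 gives > 100000 nM as a limit of the assay and not a number. Compound 2 therefore sits at the limit of > 100000 nM in this assay, at which 1 of the 2 values shown sits, and has no exact place on the scale.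

The next molecule is compound 3 `CC[C@H](C)[C@H](NC(=O)OCc1ccccc1)C(=O)N[C@@H](CC(C)C)C(=O)N[C@@H](CC(C)C)C(=O)N[C@@H](C)/C=C/C(=O)N1C(=O)C=C(OC)[C@@H]1c1c[nH]c2ccccc12` and it differs from compound 2 in one place only. The change is hydrogen in place of tert-butoxycarbonyl on an aromatic nitrogen and it puts hydrogen in place of tert-butoxycarbonyl on an aromatic nitrogen, two ring bonds from the ring atom that bears a large group.

Going by the values given here, no measured pair here differs in a single place, so the data offer no direct guide to the size of this step. Among the compounds with values here, the only firm number is that of compound 1 at 67000 nM and it anchors the expectation. A small move towards stronger inhibition in this assay is expected, and a second result reported only as a limit remains quite possible. The expected change is an at least 2.0-fold lower number from compound 2 to compound 3 (0.30 log units; that floor lies within the scatter) and it carries wide uncertainty. For compound 3 the estimated value is 50000 nM with an expected range from 10000 nM to 150000 nM.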

Compound 3, half-maximal inhibitory concentration: > 100000 nM
Compound 3 was reported as a limit (the forecaster's own chance of this, stated with the estimate: 40%); middle value at least 2.0-fold (0.30 log units) from the limit.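

Compound 3 gives > 100000 nM in this assay as a limit of the assay and not a number. Going by these compounds alone, compound 2 also stands at a limit, so no step from compound 2 to compound 3 can be read: the limit of > 100000 nM in this assay, at which 2 of the 3 values shown sit.

The compounds shown leave open whether replacing tert-butoxycarbonyl with hydrogen on the aromatic nitrogen changes the strength of inhibition at all.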